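The source may report more compounds than this note shows. Statements on the series, on what has been measured and on what is new or still open speak of the compounds shown alone.

Measured so far in a functional assay on SK-BR-3 cells (Homo sapiens) for antiproliferative activity; on this read-out lower numbers stand for stronger inhibition and higher numbers for weaker inhibition:
- Compound 1 `CCCN(CCC)CCCOc1ccc2cc(NC(=O)c3ccc(O)c(CC=C(C)C)c3)c(=O)oc2c1C`: > 50000 nM
- Compound 2 `CC(C)=CCc1cc(C(=O)Nc2cc3ccc(OCCCN(C)C4CCCCC4)c(C)c3oc2=O)ccc1O`: 970 nM

The entry for compound 1 is a limit of the assay, not a number: the limit of > 50000 nM in this assay, at which 1 of the 2 values shown sits. Among the measured compounds shown here, that leaves compound 2, at 970 nM, as the only true number and the sole reference point.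

Compound 3 `CC(C)=CCc1cc(C(=O)Nc2cc3ccc(OCCCN(C)c4ccccc4)c(C)c3oc2=O)ccc1O` alters one group of compound 2, with phenyl in place of cyclohexyl on an amine nitrogen.

For the measured compounds named here, only one measured step bears on this change, and it concerns the same amine: an at least 51-fold lower number from compound 1 to compound 2 (1.71 log units; beyond the scatter). That large step shows that this part of the molecule can matter greatly in this assay. It replaced more of the amine than the present change does, so a smaller step is expected here, probably towards weaker inhibition, though with much uncertainty. The expected step is a 2.1-fold higher number from compound 2 to compound 3 (0.31 log units; beyond the scatter). For compound 3 the estimated value is 2000 nM, with an expected range from 500 nM to 12000 nM.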

Compound 3, half-maximal inhibitory concentration: > 50000 nM
Compound 3: a limit, no number; the forecaster's own chance of this, stated with the estimate: 15%; middle value at least 25-fold (1.39 log units) away from the limit.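

Swapping cyclohexyl for phenyl on the amine nitrogen leaves the count of heavy atoms unchanged, yet it gives an at least 51-fold higher number from compound 2 to compound 3 (1.71 log units; beyond the scatter). Among the compounds shown here, the earlier step showed that the amine matters, and this one shows that the single ring on that nitrogen can decide the outcome: of the three compounds, only the one carrying cyclohexyl(methyl)amino gives a true number in this assay. Compound 3 sits at a limit of the assay, not at a number, as does compound 1, so the step from one to the other cannot be read: the limit of > 50000 nM in this assay, at which 2 of the 3 values shown sit.

From the compounds shown here alone, it remains open whether other groups on this nitrogen, such as cyclopentyl or benzyl, would give a true number. Going by these compounds, the real size of the loss from cyclohexyl to phenyl also remains open, with only a minimum known.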